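A Sulfonyl Aryl Swap in Compound 4

The compounds below may be only part of what the source reports. "The series", "measured", "known", "first", "only" and "open" are said of these compounds alone.

Measured in a functional assay on LOX IMVI cells (Homo sapiens) for cytotoxicity, read by MTT assay, with a stated time of 24 h; on this read-out higher numbers stand for weaker inhibition and lower numbers for stronger inhibition:
- compound 1 `COc1cc(-c2nc(-c3ccccc3)[nH]c2-c2ccnc(NCCCNS(=O)(=O)c3ccc(C)cc3)n2)ccc1Cl`: 18600 nM
- compound 2 `O=S(=O)(NCCCNc1nccc(-c2[nH]c(-c3ccccc3)nc2-c2ccc(Cl)c(O)c2)n1)c1ccc(Br)cc1`: 15500 nM
- compound 3 `O=S(=O)(NCCCNc1nccc(-c2[nH]c(-c3ccccc3)nc2-c2ccc(Cl)c(O)c2)n1)c1cccc(F)c1`: 33600 nM

In this assay, compound 3 gives 33600 nM, which lies within the scatter of compound 1 at 18600 nM. Compound 2 stands apart from compound 3 by a margin beyond the scatter.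

Compound 4 `Cc1ccc(S(=O)(=O)NCCCNc2nccc(-c3[nH]c(-c4ccccc4)nc3-c3ccc(Cl)c(O)c3)n2)cc1` has 4-methylphenyl in place of 3-fluorophenyl on a sulfonyl sulfur. For the measured compounds named here, only one measured step changes the group at this place: a 2.2-fold higher number from compound 2 to compound 3 (0.34 log units; beyond the scatter), a modest step, with 3-fluorophenyl in place of 4-bromophenyl. Going by the values given here, no measured step starts from or ends in 4-methylphenyl. Compound 1 also carries that group on its sulfonyl sulfur and gives 18600 nM, though its core is not the same.

A small move toward a lower number is therefore expected, not clearly beyond the scatter: a 1.5-fold lower number from compound 3 to compound 4 (0.18 log units; within the scatter). For compound 4 the estimated value is 22000 nM, with an expected range of 11000 nM to 42000 nM.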

Compound 4, half-maximal inhibitory concentration: 6020 nM
The estimate for compound 4 lay 3.7-fold (0.56 log units) above the measured number; the measured number lies below the stated range.
By their numbers in this assay, from the lowest: compound 4; then compounds 2, 1 and 3 (each within the scatter of the next, the first and the last beyond it).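

In this assay, for the compounds shown here, the group on the sulfonyl sulfur matters more than the single earlier step indicated: 4-methylphenyl in place of 3-fluorophenyl gives a larger change (a 5.6-fold lower number from compound 3 to compound 4 (0.75 log units; beyond the scatter)), even though both groups are one six-membered aromatic ring of carbon only. Methyl in place of bromo on an aromatic carbon also counts (a 2.6-fold lower number from compound 2 to compound 4 (0.41 log units; beyond the scatter)), and of the three sulfonyl groups on this shared core, 4-methylphenyl gives the lowest number. With 4-methylphenyl held constant, hydrogen in place of methyl on an oxygen on an aromatic ring adds a further difference (a 3.1-fold lower number from compound 1 to compound 4 (0.49 log units; beyond the scatter)), so this sulfonyl position is not the only place that moves the number.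

From the compounds shown here alone, whether an amine or a carboxylic acid in place of that methyl would keep the lower number remains open. Nothing given here accounts for these differences.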